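Methoxy truncation of the cyclopropylmethoxy side chain

The source may hold more compounds than are shown below. What is called first, only, known or untested is meant among the compounds shown, and "the series" means these compounds.

Going by the values given here, compound 2 `O=C(O)CCn1c(=O)oc2cc(OCC3CC3)c(Cl)cc21` gives 1580 nM in an assay on HEK293 cells for inhibition of kynurenine 3-monooxygenase (Homo sapiens), read by LC-MS, with a stated time of 20 h (a lower number here means a stronger inhibitor, a higher number a weaker inhibitor), and stands as the higher of the two numbers so far; its nearest neighbour compound 1 `CC(C)Cc1cc2oc(=O)n(CCC(=O)O)c2cc1Cl` gives 794 nM, and the step of a 2.0-fold higher number from compound 1 to compound 2 (0.30 log units; within the scatter) is within the scatter. The next compound, compound 3 `COc1cc2oc(=O)n(CCC(=O)O)c2cc1Cl`, differs from compound 2 by hydrogen in place of cyclopropyl on a saturated chain carbon bound to an oxygen on an aromatic ring. Among the compounds with values here, no measured step concerns this change directly; the only step so far, from isobutyl to cyclopropylmethoxy, is the one noted above and was within the scatter, so it offers no anchor for the direction of the new step. The expectation for compound 3 in this assay is therefore a step of a 1.6-fold higher number from compound 2 to compound 3 (0.20 log units; within the scatter) of modest size, direction uncertain, with the range kept wide. Compound 3 is estimated at 2500 nM, with a range from 800 nM to 8000 nM.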

Compound 3, half-maximal inhibitory concentration in the kynurenine 3-monooxygenase assay: 5010 nM
Compound 3: the middle estimate sits 2.0-fold (0.30 log units) below what was measured, and the stated range covers the measured number.
By their numbers in the kynurenine 3-monooxygenase assay, from the lowest: compounds 1 and 2 (each within the scatter of the next); then compound 3.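

In the kynurenine 3-monooxygenase assay, methoxy separates from the two longer side chains, giving the steps beyond the scatter a 3.2-fold higher number from compound 2 to compound 3 (0.50 log units; beyond the scatter) and a 6.3-fold higher number from compound 1 to compound 3 (0.80 log units; beyond the scatter), whereas isobutyl and cyclopropylmethoxy stay within the scatter of each other, with a 2.0-fold higher number from compound 1 to compound 2 (0.30 log units; within the scatter). In a physicochemical assay for permeability, using PAMPA (a lower number here means that the compound crosses the layer more slowly, a higher number that the compound crosses the layer faster), compound 2 gives 19 nm/s, and removing the cyclopropyl also gives an at least 6.3-fold lower number from compound 2 to compound 3 (0.80 log units; beyond the scatter). In the physicochemical assay, compound 3 gives < 3 nm/s, which is a limit of the assay and not a number: the limit of < 3 nm/s in the physicochemical assay, at which 1 of the 2 values shown sits.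

As far as these compounds go, three side chains cannot show whether the number in the kynurenine 3-monooxygenase assay follows chain length, so it remains open where between methyl and cyclopropylmethyl on this oxygen the step arises, and an ethoxy or a propoxy chain would bear on this. Also open, from the compounds shown here alone, is whether a hydroxyl or an amine on this aromatic carbon would stand with methoxy or with the longer side chains.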